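A few compounds are considered here, and "the series" means these few. Any claim that something is new, unique, unknown or untested is made for them only; others in the source may bear on it.

Of the compounds shown here, three built on one shared core have been tested in a functional assay (Cavia porcellus) with sulfonylurea receptors; K-ATP channels (Homo sapiens) as the target; a higher number here means a weaker inhibitor, a lower number a stronger inhibitor. Compound 1 `CC(O)(C(=O)Nc1ccc(S(=O)(=O)c2ccccc2)c(Cl)c1)C(F)(F)F` gives 2200 nM. Compound 2 `Cc1cc(NC(=O)C(C)(O)C(F)(F)F)ccc1S(=O)(=O)c1ccccc1` gives 1600 nM. Compound 3 `CC(O)(C(=O)Nc1ccc(S(=O)(=O)c2ccccc2)c(C(F)(F)F)c1)C(F)(F)F` is reported only as a limit of the assay, > 30000 nM, and not as a number. That places compound 3 at the weak end of everything measured here, sitting at the limit of > 30000 nM in this assay, at which 1 of the 3 values shown sits. The other two compounds sit close together, with a 1.4-fold lower number from compound 1 to compound 2 (0.14 log units; within the scatter). The two steps that end at the limit are large: an at least 13-fold higher number from compound 1 to compound 3 (1.13 log units; beyond the scatter) and an at least 18-fold higher number from compound 2 to compound 3 (1.27 log units; beyond the scatter).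

Compound 4 `CC(O)(C(=O)Nc1ccc(S(=O)(=O)c2ccccc2)c(C(=O)O)c1)C(F)(F)F` has not yet been measured. It differs from compound 3 in one place: carboxy in place of trifluoromethyl on an aromatic carbon. Among the measured compounds shown here, none of the measured steps swaps a trifluoromethyl for a carboxy, so they bear on this change only indirectly, by showing that chloro or methyl in that place gave far lower numbers than trifluoromethyl. Because compound 3 stands only at a limit > 30000 nM, the size of any step from it is uncertain. Compound 4 is therefore expected to give a lower number, with the step estimated as an at least 2.0-fold lower number from compound 3 to compound 4 (0.30 log units; that floor lies within the scatter). The estimate for compound 4 is 15000 nM, with a range from 2500 nM to 60000 nM, and it may itself be reported only as a limit.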

Compound 4, half-maximal inhibitory concentration: > 30000 nM
Compound 4 gave a limit, no number (the forecaster's own chance of this, stated with the estimate: 40%); middle value at least 2.0-fold (0.30 log units) away from the limit.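

The carboxy group, ortho to a phenylsulfonyl group, is a second replacement at this place that gives a far weaker result than methyl or chloro in this assay, with an at least 18-fold higher number from compound 2 to compound 4 (1.27 log units; beyond the scatter) and an at least 13-fold higher number from compound 1 to compound 4 (1.13 log units; beyond the scatter). Compound 3 is therefore no lone case: of the four groups shown at this place, chloro and methyl give a readable number, while trifluoromethyl and carboxy do not. Neither compound 3 nor compound 4 has a number, so the step between them cannot be read, and the set now divides into two compounds with values and two at the same assay limit: the limit of > 30000 nM in this assay, at which 2 of the 4 values shown sit.

From the compounds shown here alone, how far compound 3 and compound 4 really lie beyond that limit stays open, as does what sets their groups apart from chloro and methyl, since trifluoromethyl has no hydrogen-bond donor and carboxy has one, yet both end at the limit. Going by these compounds, whether a nitrile, an amine or a methyl ester at this place would give a readable number like chloro and methyl, or would also end at the limit, also remains open.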